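Swapping 2-chlorophenyl for benzyloxy on a shared thiazolidinedione core

The source may hold more compounds than are shown below. What is called first, only, known or untested is meant among the compounds shown, and "the series" means these compounds.

Measured so far in a functional assay on the whole organism (plasma) with Mus musculus as the target, with a stated time of 15 days, at a dose of 20 mg/kg by the oral route; a lower number here means a weaker effect, a higher number a stronger effect of the compound at the dose given:
Compound 1 `Cc1ccc(CN2C(=O)S/C(=C\c3ccc(N(C)C)cc3)C2=O)cc1` gives 17.4%.
Compound 2 `Cc1ccc(CN2C(=O)S/C(=C\c3ccccc3Cl)C2=O)cc1` gives 20%.

Of the two numbers, compound 2 gives the higher one, but its distance from compound 1 lies within the usual scatter of this assay, so the two compounds cannot be told apart on these data. Both read-outs are modest.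

Compound 3 `Cc1ccc(CN2C(=O)S/C(=C\OCc3ccccc3)C2=O)cc1` has not yet been measured. It differs from compound 2 in one place: benzyloxy in place of 2-chlorophenyl on a double-bonded chain carbon bound to a double-bonded ring carbon. Among the measured compounds shown here, no measured pair shows what such a change does here, so no step size is known from the data.

Compound 3 is expected to give 15%, within a range from 4% to 30%. That estimate means a step of a number 5 percentage points lower from compound 2 to compound 3 (within the scatter) in this assay, which is expected to remain within the scatter rather than mark a clear rise or fall.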

Compound 3, a percentage reported as activity, at one dose (the size of the read-out at that dose, not a potency): 45.2%
For compound 3 the middle estimate is 30.2 percentage points below the measured one; measured number outside the range, above it.
By their numbers in this assay, from the lowest: compounds 1 and 2 (each within the scatter of the next); then compound 3.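

Among the compounds shown here, this is the first measured step at this position. In this assay the change gives a number 25.2 percentage points higher from compound 2 to compound 3 (beyond the scatter) and so shows that the group on the double-bonded chain carbon bound to a double-bonded ring carbon can move the read-out by more than the usual scatter. Benzyloxy and 2-chlorophenyl each carry a six-membered aromatic ring of carbon only, so the step goes with the other differences, the oxygen entering and the chlorine leaving, and this one pair cannot separate those two. Nothing measured here explains the rise.

From the compounds shown here alone, it stays open whether the oxygen or the aromatic ring matters more for the higher number. Methoxy, which keeps the oxygen without the ring, and benzylamino, which has nitrogen in place of the oxygen, would each test part of that question.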